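Aryl and benzyl groups on the sulfonamide nitrogen

The source may report more compounds than this note shows. Statements on the series, on what has been measured and on what is new or still open speak of the compounds shown alone.

Measured compounds:
compound 1 `CC(C)CN(Cc1ccccc1C(F)(F)F)S(=O)(=O)c1ccc2c(c1)C(O)CC(C1CCOCC1)O2`, 4.23
compound 2 `Cc1ccc(N(CC(C)C)S(=O)(=O)c2ccc3c(c2)C(O)CC(C2CCOCC2)O3)c(C)c1`, 4.19
compound 3 `CC(C)CN(C1CCc2ccc(F)cc21)S(=O)(=O)c1ccc2c(c1)C(O)CC(C1CCOCC1)O2`, 3.94

In a physicochemical assay for lipophilicity, at pH 7.4 (a higher number here means a more lipophilic compound, a lower number a more polar compound), compound 3 gives 3.94, the lowest of the three numbers, yet its gaps to the other two are within the scatter: a number 0.25 log units lower from compound 2 to compound 3 (within the scatter) and a number 0.29 log units lower from compound 1 to compound 3 (within the scatter). Likewise a number 0.04 log units lower from compound 1 to compound 2 (within the scatter). All three compounds share a core and differ only in the group on the sulfonamide nitrogen.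

Compound 4 `CC(C)CN(c1cc2ccccc2s1)S(=O)(=O)c1ccc2c(c1)C(O)CC(C1CCOCC1)O2` has not yet been measured. It differs from compound 3 in one place:

1-benzothiophen-2-yl in place of 6-fluoro-2,3-dihydro-1H-inden-1-yl on a sulfonamide nitrogen

Every measured exchange at this position, whether between a benzyl, an aryl or a saturated bicyclic group, left the number within the scatter. On that basis a step of a number 0.16 log units higher from compound 3 to compound 4 (within the scatter) is expected, that is, none beyond the scatter, in this assay. Compound 4 is therefore estimated at 4.1, within a range from 3.7 to 4.5.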

Compound 4, distribution coefficient: 3.92
Compound 4: middle estimate off by 0.18 log units, on the high side, and the stated range covers the measured number.
By their numbers in this assay, from the lowest: compounds 4, 3, 2 and 1 (each within the scatter of the next, the first and the last beyond it).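

With the 1-benzothiophen-2-yl group on the sulfonamide nitrogen, this assay gives a number 0.02 log units lower from compound 3 to compound 4 (within the scatter) and a number 0.27 log units lower from compound 2 to compound 4 (within the scatter), so this group does not separate from 6-fluoro-2,3-dihydro-1H-inden-1-yl or 2,4-dimethylphenyl. Against 2-(trifluoromethyl)benzyl, however, it gives a number 0.31 log units lower from compound 1 to compound 4 (beyond the scatter), the first step at this position to pass the scatter, and only a modest one. Nothing presented here accounts for that single step.

Going by these compounds, whether a group of another kind at this position, such as an amine or a carboxylic acid, would produce a larger step remains open. On these data alone, it is also open whether 1-benzofuran-2-yl, with oxygen in the five-membered ring in place of sulfur, would stand with compound 4 in this assay.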